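Aminomethyl in place of methoxy on a fluorinated core

The source may hold more compounds than are shown below. What is called first, only, known or untested is meant among the compounds shown, and "the series" means these compounds.

Measured compounds:
Compound 1 `COc1c(F)c(N)c2c(=O)cc(-c3ccc(N)c(F)c3)oc2c1F`: 34000 nM
Compound 2 `COCc1c(F)c(N)c2c(=O)cc(-c3ccc(N)c(F)c3)oc2c1F`: > 100000 nM
Compound 3 `CN(C)CCCOCc1c(F)c(N)c2c(=O)cc(-c3ccc(N)c(F)c3)oc2c1F`: 12000 nM

In a functional assay on HeLa cells (Homo sapiens) for cytotoxicity, read by neutral red uptake, with a stated time of 3 days (a lower number here means a stronger inhibitor, a higher number a weaker inhibitor), compound 1 gives 34000 nM, the highest of the two numbers recorded. The nearest step is a 2.8-fold lower number from compound 1 to compound 3 (0.45 log units; beyond the scatter). Compound 2 reaches only (the limit of > 100000 nM in this assay, at which 1 of the 3 values shown sits), so its result is a limit rather than a number.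

Compound 4 `NCc1c(F)c(N)c2c(=O)cc(-c3ccc(N)c(F)c3)oc2c1F` differs from compound 1 in one place: aminomethyl in place of methoxy on an aromatic carbon. Going by the values given here, three measured steps bear on this change. Swapping the methoxy for a methoxymethyl gave an at least 2.9-fold higher number from compound 1 to compound 2 (0.46 log units; beyond the scatter). Swapping it for a (3-(dimethylamino)propoxy)methyl gave a 2.8-fold lower number from compound 1 to compound 3 (0.45 log units; beyond the scatter). Adding a 2-(dimethylamino)ethyl to the saturated chain carbon bound to an oxygen gave an at least 8.3-fold lower number from compound 2 to compound 3 (0.92 log units; beyond the scatter). The amine-bearing substituent thus gave the lowest number of the three, while the neutral methoxymethyl gave a limit; aminomethyl carries a nitrogen but a shorter chain than compound 3. A small lowering, near the edge of the scatter, is therefore expected: a 1.7-fold lower number from compound 1 to compound 4 (0.23 log units; within the scatter). Compound 4 is estimated at 20000 nM, with a range from 6000 nM to 70000 nM.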

Compound 4, half-maximal inhibitory concentration: 8800 nM
Compound 4: middle estimate off by 2.3-fold (0.36 log units), on the high side, within the range that was stated.
By their numbers in this assay, from the lowest: compounds 4 and 3 (each within the scatter of the next); then compound 1. At a limit, above all of these: compound 2.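

Aminomethyl on this aromatic carbon, ortho to two fluoro groups, brings a change that the methoxymethyl of the earlier series did not: with the same count of heavy atoms as the methoxy it replaces, it gives a 3.9-fold lower number from compound 1 to compound 4 (0.59 log units; beyond the scatter). The long chain is not required to reach this level, as amino in place of 3-(dimethylamino)propoxy gives a 1.4-fold lower number from compound 3 to compound 4 (0.13 log units; within the scatter), while amino in place of methoxy on the saturated chain carbon gives an at least 11-fold lower number from compound 2 to compound 4 (1.05 log units; beyond the scatter). Compound 2 stands at a limit rather than a number: the limit of > 100000 nM in this assay, at which 1 of the 4 values shown sits.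

How a hydroxymethyl, a dimethylaminomethyl or a two-carbon aminoethyl chain would read on this aromatic carbon stays open, so the compounds shown cannot separate the presence of the nitrogen from the length of the chain that carries it. They also leave open whether the amide of the aminomethyl group, or an amine placed directly on this carbon, would keep the number where compounds 3 and 4 lie.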